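A few compounds are considered here, and "the series" means these few. Any claim that something is new, unique, unknown or untested is made for them only; others in the source may bear on it.

Working notes on the series, read in an ADME assay on HaCaT cells (Homo sapiens) for cytotoxicity, read by MTT assay, with a stated time of 48 h; a higher number here means a weaker inhibitor, a lower number a stronger inhibitor. Compound 2 (`COc1ccc2[nH]c(-c3cn(-c4ccccc4)nc3-c3ccc(F)cc3)nc2c1`) gives > 50000 nM, which is a limit and not a number. Compound 1 (`Fc1ccc(-c2nn(-c3ccccc3)cc2-c2nc3cc(F)ccc3[nH]2)cc1`) gives > 50000 nM, also a limit. Compound 3 (`O=C(OCc1ccccc1)c1ccc2[nH]c(-c3cn(-c4ccccc4)nc3-c3ccc(F)cc3)nc2c1`) gives > 50000 nM, again a limit. All three compounds therefore share (the limit of > 50000 nM in this assay, at which 3 of the 3 values shown sit), and compound 2 has no readable rank among them.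

Compound 4 (`COc1ccc2[nH]c(-c3cn(-c4ccccc4)nc3-c3ccc(Cl)cc3)nc2c1`) departs from compound 2 at one place: chloro in place of fluoro on an aromatic carbon. This is chloro in place of fluoro on an aromatic carbon, para to a large group, so 4-fluorophenyl becomes 4-chlorophenyl.

For the measured compounds named here, no measured step changes this group. The three available steps replace a different group on an aromatic carbon, and they offer no size to carry over: a step that the two limits leave unreadable from compound 1 to compound 2, a step that the two limits leave unreadable from compound 1 to compound 3 and a step that the two limits leave unreadable from compound 2 to compound 3. They show only that these replacements left every compound at the limit.

In this assay, no step beyond the usual scatter is expected, and no direction can be assigned. The estimated change is a step that the limit leaves unreadable from compound 2 to compound 4, and a report as a limit is the likeliest outcome. The expected value for compound 4 is 60000 nM, with an estimated range from 30000 nM to 120000 nM.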

Compound 4, half-maximal inhibitory concentration: > 50000 nM
Compound 4: no number, only a limit; the forecaster's own chance of this, stated with the estimate: 85%; the middle value is on the limit's open side.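

For the compounds shown here, compound 4 gives a limit and not a number, as compound 2 does, so no step between compound 2 and compound 4 can be read, either in size or in direction. The compounds shown leave open how far any of them differs from the others, and whether any change to the shared core gives a readable value: the limit of > 50000 nM in this assay, at which 4 of the 4 values shown sit.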